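The compounds below may be only part of what the source reports. "The series", "measured", "known", "first", "only" and "open" are said of these compounds alone.

Measured in an ADME assay on Vero cells (Chlorocebus sabaeus) for cytotoxicity, read by MTT assay, with a stated time of 96 h; on this read-out higher numbers stand for lower toxicity in this test and lower numbers for higher toxicity in this test:
- compound 1 `CC(=O)c1ccc2[nH]c(-c3ccoc3)nc2c1`: > 100000 nM
- compound 2 `C/C(=N\NC(N)=S)c1ccc2c(c1)nc(-c1ccoc1)n2C1CCCCC1`: 25000 nM

The entry for compound 1 is a limit of the assay, not a number. Going by the values given here, compound 2 gives 25000 nM, the only true number so far in this assay.

Compound 3 `C/C(=N\NC(N)=S)c1ccc2[nH]c(-c3ccoc3)nc2c1` has hydrogen in place of cyclohexyl on an aromatic nitrogen of compound 2: hydrogen in place of cyclohexyl on an aromatic nitrogen. Among the compounds with values here, no measured step shows this change on its own. Compound 1, which also has hydrogen on that nitrogen but differs elsewhere, stands at the limit of > 100000 nM. A moderate shift towards lower toxicity is therefore expected, and a result at the limit would not surprise. The estimated step is a 2.4-fold higher number from compound 2 to compound 3 (0.38 log units; beyond the scatter). For compound 3 the expected value is 60000 nM, with an estimated range of 20000 nM to 100000 nM.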

Compound 3, half-maximal cytotoxic concentration: 100000 nM
Estimate against measurement, compound 3: 1.7-fold (0.22 log units) below; low and high end bracket the measured number.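

In this assay, hydrogen in place of cyclohexyl on an aromatic nitrogen gives a modest step: a 4.0-fold higher number from compound 2 to compound 3 (0.60 log units; beyond the scatter). Cyclohexyl at this position therefore goes with the higher toxicity in this pair, although this rests on a single matched pair. The change on the aromatic carbon gives a number no higher from compound 1 to compound 3 (the limit leaves the size open), and the size of this step cannot be read. The entry for compound 1 is a limit of the assay, and the size stays open because of it: the limit of > 100000 nM in this assay, at which 1 of the 3 values shown sits.

Still open, on these data alone, is whether the shift depends on the cyclohexyl ring itself or on any group larger than hydrogen on that nitrogen; a methyl group or an open chain such as n-butyl there would separate the two. Also open, as far as these compounds go, is how a phenyl ring in place of furan-3-yl would change the number.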